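The source may hold more compounds than are shown below. What is called first, only, known or untested is meant among the compounds shown, and "the series" means these compounds.

In a functional assay on PC-3 cells (Homo sapiens) for antiproliferative activity, read by MTT assay, tested at 1 uM (on this read-out lower numbers stand for a weaker effect and higher numbers for a stronger effect at the one concentration tested), compound 1 `COc1cc(C(=O)N/N=C/c2ccc(F)c(F)c2)cc(OC)c1OC` gives 35.1%, the higher of the two numbers in hand. Compound 2 `COc1cc(C2=NN(C(C)=O)C(c3c(Cl)cccc3Cl)O2)cc(OC)c1OC`, built on a different core, gives 5.1%, which sits beyond the scatter below the value of compound 1. Compound 3 `COc1cc(C(=O)N/N=C/c2ccc(Cl)c(Cl)c2)cc(OC)c1OC` keeps the core of compound 1 and differs from it in one place: 3,4-dichlorophenyl in place of 3,4-difluorophenyl on a carbon with a double bond to nitrogen. Going by the values given here, no measured pair shows what this exchange does here, so the step is expected to be small, in either direction or none beyond the scatter. The estimate for compound 3 is 38%, in the range 15% to 60%. For compound 3 this means an expected step of a number 2.9 percentage points higher from compound 1 to compound 3 (within the scatter).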

Compound 3, a percentage reported as inhibition, at one concentration (the size of the read-out at that concentration, not a potency): 13.5%
Compound 3: the middle estimate sits 24.5 percentage points above what was measured; the whole stated range lies above it.
By their numbers in this assay, from the lowest: compounds 2 and 3 (each within the scatter of the next); then compound 1.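

In this assay, 3,4-dichlorophenyl in place of 3,4-difluorophenyl on a carbon with a double bond to nitrogen gives a number 21.6 percentage points lower from compound 1 to compound 3 (beyond the scatter). This position on the core of compound 1 therefore responds to the exchange of fluorine for chlorine, although the two groups match in heavy atoms, ring, hydrogen-bond donors and acceptors, and charge. No measurement at hand accounts for the step.

As far as these compounds go, whether an unsubstituted phenyl, a methoxyphenyl or an aminophenyl at this place would stand nearer compound 1 or compound 3 remains open. This single pair also leaves open how each of the two halogens contributes.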